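This account rests on a few compounds, and the source may have more. Where it says the series, first, only, none or still open, it means among the compounds named here.

Compound 1 `CCOC(=O)c1c(-c2cccc(OC)c2)[nH]c2cc(OC)c(F)cc2c1=O`: > 21500 nM
Compound 2 `CCOC(=O)c1c(-c2cccc(OC(F)(F)F)c2)[nH]c2cc(OC)c(F)cc2c1=O`: > 21500 nM
Compound 3 `CCOC(=O)c1c(-c2cccc(Oc3c(C)cccc3C)c2)[nH]c2cc(OC)c(F)cc2c1=O`: > 21500 nM

All three compounds were tested in an ADME assay on HepG2 cells (Homo sapiens) for cytotoxicity, read by luminescence, with a stated time of 72 h (on this read-out higher numbers stand for an effect only at larger amounts of compound and lower numbers for an effect already at smaller amounts), and each entry is a limit of the assay and not a number. Compound 3 therefore has no exact position, only its limit of > 21500 nM. It shares that position with the other two compounds: the limit of > 21500 nM in this assay, at which 3 of the 3 values shown sit.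

Compound 4 `CCOC(=O)c1c(-c2cccc(Cc3nc(C)c(C)s3)c2)[nH]c2cc(OC)c(F)cc2c1=O` keeps the shared core and differs from compound 3 in one group: a group of 8 heavy atoms (6 carbon, 1 nitrogen, 1 sulfur; one five-membered aromatic ring with 2 hetero atoms) in place of a group of 9 heavy atoms (8 carbon, 1 oxygen; one six-membered aromatic ring of carbon only), on an aromatic carbon. The 2,6-dimethylphenoxy group leaves, and a five-membered aromatic ring with 2 hetero atoms enters with its substituents.

Within the data shown here, three measured steps bear on this change, though only loosely: a step that the two limits leave unreadable from compound 1 to compound 2, a step that the two limits leave unreadable from compound 1 to compound 3 and a step that the two limits leave unreadable from compound 2 to compound 3. All three exchange a group on an oxygen on an aromatic ring, and none has a readable size. None of them brings in a group of the kind found in compound 4.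

The series gives no measured direction, so no step beyond the scatter is expected in this assay. For the change to compound 4, the expected result is a number no higher from compound 3 to compound 4 (the limit leaves the size open). The estimate for compound 4 is 21500 nM, with an expected range of 10000 nM to 40000 nM.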

Compound 4, half-maximal effective concentration: > 21500 nM
Compound 4 was reported as a limit; the forecaster's own chance of this, stated with the estimate: 80%; the middle value sits exactly at the limit.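

Among these compounds, compound 4 is reported only as a limit in this assay, so no step between it and compound 1, compound 2 or compound 3 can be read. It shares its position with them: the limit of > 21500 nM in this assay, at which 4 of the 4 values shown sit.

The compounds shown leave open at what concentration compound 1, compound 2, compound 3 or compound 4 would give a half-maximal effect, and whether their groups differ at all in this assay.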